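The source may hold more compounds than are shown below. What is called first, only, known or untested is meant among the compounds shown, and "the series" means these compounds.

So far only two compounds have numbers in a physicochemical assay for lipophilicity, measured as octanol-water partition; a higher number here means a more lipophilic compound, a lower number a more polar compound. Compound 1 (`CCCc1cn(C/C=C(/C)CCC=C(C)C)nn1`) gives 4.05, while compound 2 (`COC(=O)c1cn(CC=C(C)C)nn1`) gives 1.3. Compound 2 therefore stands lowest of the two, with a gap to compound 1 that lies beyond the scatter. Compound 3 (`CCCc1cn(CC=C(C)C)nn1`) is not yet measured. It has propyl in place of methoxycarbonyl on an aromatic carbon. Among the compounds with values here, no measured step shows this exchange directly, so the expectation is only a rough one. Compound 3 is expected to rise in this assay beyond the scatter, yet to stay under compound 1, which also carries propyl and gives 4.05. The expected size of the change is a number 1.20 log units higher from compound 2 to compound 3 (beyond the scatter). The estimated value for compound 3 is 2.5, with an expected range from 2.1 to 3.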

Compound 3, partition coefficient: 2.47
Beside the measured number, compound 3's estimate is 0.03 log units above it; low and high end bracket the measured number.
By their numbers in this assay, from the lowest: compound 2; then compound 3; then compound 1.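

With a number 1.17 log units higher from compound 2 to compound 3 (beyond the scatter) in this assay, the exchange of methoxycarbonyl for propyl on the aromatic carbon now has a direct measured step, and it is large. Compound 3 also isolates the chain on the other side of the molecule: with propyl held in place, hydrogen in place of 3-methylbut-2-en-1-yl on a saturated chain carbon bound to a double-bonded chain carbon gives a number 1.58 log units lower from compound 1 to compound 3 (beyond the scatter) as a second large step. No measurement at hand gives a reason for either step.

The compounds shown leave open where a butyl chain, an amine or a carboxylic acid on that aromatic carbon would fall in this assay among these values. They also leave open whether methoxycarbonyl in place of propyl would shift the number by a similar amount on the core of compound 1.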